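The compounds below may be only part of what the source reports. "The series", "measured", "known", "first", "only" and "open" are said of these compounds alone.

Compound 1 `COc1cccc(S(=O)(=O)c2cccc3oc(N4CCNCC4)nc23)c1`: 25 nM
Compound 2 `O=S(=O)(c1cccc2ccccc12)c1cccc2oc(N3CCNCC3)nc12`: 3.1 nM

In an assay on HeLa cells for displacement of a labelled ligand from 5-hydroxytryptamine receptor 6 (Homo sapiens) (a lower number here means a stronger inhibitor, a higher number a weaker inhibitor), compound 2 gives 3.1 nM, the lower of the two numbers measured, and in the same assay compound 1 gives 25 nM, a gap beyond the usual scatter. Compound 3 `CCCCN1CCN(c2nc3c(S(=O)(=O)c4cccc5ccccc45)cccc3o2)CC1` keeps the core of compound 2 and differs from it in one place: butyl in place of hydrogen on an amine nitrogen in a ring. Among the compounds with values here, no measured pair shows this change, so its effect is not known from the data. A modest weakening is expected, and compound 3 is estimated at 8 nM, within 2 nM to 30 nM, which would mean a step of a 2.6-fold higher number from compound 2 to compound 3 (0.41 log units; beyond the scatter).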

Compound 3, inhibition constant: 88 nM
Estimate against measurement, compound 3: 11-fold (1.04 log units) below; the whole stated range lies below it.
By their numbers in this assay, from the lowest: compound 2; then compound 1; then compound 3.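

In this assay, putting butyl on the amine nitrogen in the ring weakens binding markedly (a 28-fold higher number from compound 2 to compound 3 (1.45 log units; beyond the scatter)). Within the data shown here, this shows that the position, which does not vary between the earlier compounds, is sensitive to substitution, at least by this chain. No measurement shown here explains the loss. On these data alone, it remains open whether methyl or a hydroxyethyl group on that nitrogen would cost less than butyl, and whether butyl would have a similar effect on the core of compound 1.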